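Bromo for Chloro: Predicting a Second Halogen Swap

The source may report more compounds than this note shows. Statements on the series, on what has been measured and on what is new or still open speak of the compounds shown alone.

Of the compounds shown here, three have been measured in a functional assay on A549 cells (Homo sapiens) for cytotoxicity, read by XTT assay, with a stated time of 24 h; a higher number here means a weaker inhibitor, a lower number a stronger inhibitor. Compound 1 `Cn1nnnc1SCC(=O)N/N=C/c1ccccc1Cl` gives 6320000 nM in this assay, compound 3 `Cn1nnnc1SCC(=O)N/N=C/c1ccccc1Br` gives 2000000 nM, and compound 2 `Cn1nnnc1SCC(=O)N/N=C/c1cccc(Cl)c1` gives 7500000 nM. Among the compounds with values here, the only counted change between compound 1 and compound 3 is bromo in place of chloro on an aromatic carbon, and this change produced a 3.2-fold lower number from compound 1 to compound 3 (0.50 log units; beyond the scatter). Compound 1 and compound 2 are built from the same atoms joined differently, and the difference between their two cores is not broken down here.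

Compound 4 `Cn1nnnc1SCC(=O)N/N=C/c1cccc(Br)c1` has not yet been measured in this assay. Compared with compound 2, its change is bromo in place of chloro on an aromatic carbon. Within the data shown here, this is the same kind of change as the one from compound 1 to compound 3, but the place differs: in compound 3 the bromo sits ortho to a large group, whereas in compound 4 it sits meta to a large group.

Resting on the one measured example, a 3.2-fold lower number from compound 1 to compound 3 (0.50 log units; beyond the scatter), the step from compound 2 to compound 4 is expected to be a 3.0-fold lower number from compound 2 to compound 4 (0.48 log units; beyond the scatter). Compound 4 is therefore estimated at 2500000 nM, with a likely range from 1200000 nM to 5500000 nM.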

Compound 4, half-maximal inhibitory concentration: 600000 nM
Compound 4: middle estimate off by 4.2-fold (0.62 log units), on the high side, outside the stated range (below it).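

The swap of chloro for bromo on an aromatic carbon gave a 13-fold lower number from compound 2 to compound 4 (1.10 log units; beyond the scatter) in this assay. The number fell on both cores, but the size of the step did not carry over from one to the other: the same change on two cores in this assay, a 3.2-fold lower number (0.50 log units; beyond the scatter) from compound 1 to compound 3 and a 13-fold lower number (1.10 log units; beyond the scatter) from compound 2 to compound 4, 4.0-fold (0.60 log units) apart, beyond the scatter of two such steps

For these two pairs, then, the earlier step pointed the right way but did not fix how far the number would move, and these data do not show why the sizes differ, nor can two pairs tell whether the place of the halogen on the ring is what matters.

The compounds shown carry only chloro or bromo on the ring, which leaves open how fluoro, iodo or methoxy would behave in the same places. Also open, on these data alone, is whether an amine or a carboxylic acid on that ring would fit the same picture, and whether the bromo swap would give a similar step on any further core.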